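A 5-chloro-2-hydroxyphenyl group replaces pyridin-2-yl

The source may report more compounds than this note shows. Statements on the series, on what has been measured and on what is new or still open speak of the compounds shown alone.

Measured in a functional assay on SMMC-7721 cells (Homo sapiens) for antiproliferative activity, read by MTT assay, with a stated time of 72 h; on this read-out higher numbers stand for weaker inhibition and lower numbers for stronger inhibition:
- Compound 1 (`C/C(=N\NC(=O)c1cccc(S(=O)(=O)N2CCOCC2)c1)c1cccc(O)c1`) gives > 100000 nM as a limit
- Compound 2 (`C/C(=N\NC(=O)c1cccc(S(=O)(=O)N2CCOCC2)c1)c1cc(Br)ccc1O`) gives 2410 nM as a number
- Compound 3 (`O=C(N/N=C/c1ccccn1)c1cccc(S(=O)(=O)N2CCOCC2)c1`) gives > 100000 nM as a limit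

Compound 3 sits at the limit of > 100000 nM in this assay, at which 2 of the 3 values shown sit, and so has no measured number. Compound 4 (`O=C(N/N=C/c1cc(Cl)ccc1O)c1cccc(S(=O)(=O)N2CCOCC2)c1`) differs from it in one place, with 5-chloro-2-hydroxyphenyl in place of pyridin-2-yl on a carbon with a double bond to nitrogen is the count of that change. Among the compounds with values here, the one measured step that bears on it is an at least 41-fold lower number from compound 1 to compound 2 (1.61 log units; beyond the scatter) where 5-bromo-2-hydroxyphenyl took the place of 3-hydroxyphenyl. That step was large and beyond the scatter, but it involved neither chlorine nor pyridin-2-yl, so it guides the expectation only loosely. A large step towards lower numbers is therefore expected in this assay with compound 2 at 2410 nM as the nearest measured relative. The estimated change is an at least 25-fold lower number from compound 3 to compound 4 (1.39 log units; beyond the scatter) and would lie beyond the scatter. For compound 4 the estimated value is 4000 nM with an expected range from 800 nM to 30000 nM around it.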

Compound 4, half-maximal inhibitory concentration: 6820 nM
The estimate for compound 4 lay 1.7-fold (0.23 log units) below the measured number, and the stated range covers the measured number.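

In this assay, putting 5-chloro-2-hydroxyphenyl in place of pyridin-2-yl on the carbon with a double bond to nitrogen gives an at least 14-fold lower number from compound 3 to compound 4 (1.16 log units; beyond the scatter). A large step at this place therefore no longer rests on 5-bromo-2-hydroxyphenyl alone: it also appears with a chlorine-bearing group, and starting from a different group, pyridin-2-yl rather than 3-hydroxyphenyl. Compound 3 stands only at a limit, so this step has a floor and no exact size: the limit of > 100000 nM in this assay, at which 2 of the 4 values shown sit.

The change swaps the ring, adds the hydroxyl and adds the chlorine all at once, so the step cannot say which of these carries it. Going by these compounds, how a plain 2-hydroxyphenyl without halogen, or a methoxy group in place of the hydroxyl, would stand remains open.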